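The compounds below may be only part of what the source reports. "The series", "measured", "known", "first", "only" and "open" are said of these compounds alone.

Compound 1 `Nc1nc(N2CCCC2)sc1C(=O)/C=C/c1ccccc1` gives 29.6 ug/mL in a functional assay on HepG2 cells (Homo sapiens) for antiproliferative activity, read by MTT assay, with a stated time of 48 h; a higher number here means a weaker inhibitor, a lower number a stronger inhibitor. Compound 2 `Nc1nc(N2CCCC2)sc1C(=O)/C=C/c1ccc(Cl)cc1Cl` differs from compound 1 in several places; in this assay compound 2 gives 10.6 ug/mL. For the measured compounds named here, compound 3 `Nc1nc(N2CCCCC2)sc1C(=O)/C=C/c1ccccc1` gives 16.6 ug/mL in this assay; the single one-point step measured so far, a 1.8-fold lower number from compound 1 to compound 3 (0.25 log units; within the scatter), stays within the scatter. On the numbers to date compound 3 stands second highest of three, within the scatter of both compound 2 and compound 1, so no order among them can be claimed. Compound 4 `Nc1nc(N2CCCCC2)sc1C(=O)/C=C/c1ccc([N+](=O)[O-])cc1` differs from compound 3 by nitro in place of hydrogen on an aromatic carbon. Going by the values given here, no measured step bears directly on this change: no compound here carries a nitro group, and the only substitution of the aromatic ring seen, compound 1 to compound 2, is a change in two places, where compound 2 gives 10.6 ug/mL and compound 1 gives 29.6 ug/mL. The step from compound 3 to compound 4 is therefore expected to be modest, a 1.4-fold lower number from compound 3 to compound 4 (0.14 log units; within the scatter), at most a small move toward a lower number. Compound 4 is estimated at 12 ug/mL, with a range of 5 ug/mL to 30 ug/mL.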

Compound 4, half-maximal inhibitory concentration: 15.4 ug/mL
The estimate for compound 4 lay 1.3-fold (0.11 log units) below the measured number; measured number inside the range.
By their numbers in this assay, from the lowest: compounds 2, 4, 3 and 1 (each within the scatter of the next, the first and the last beyond it).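

In this assay, nitro in place of hydrogen on an aromatic carbon, para to a large group, gives a 1.1-fold lower number from compound 3 to compound 4 (0.03 log units; within the scatter), a step that stays within the scatter, so this place on the ring accepts the nitro group and its 3 heavy atoms with no readable difference in the number. The earlier compounds shown here could not show this, since their only substitution of this ring, in compound 2, differs from compound 1 in two places. Nothing measured here accounts for this result.

Open, as far as these compounds go, is whether an amine or a methoxy group on the same carbon would also stay within the scatter of compound 3. Also open, from the compounds shown here alone, is whether nitro on the same carbon would give a similar step with pyrrolidin-1-yl in place of piperidin-1-yl.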